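Aryl exchange on the five-membered ring: toward compound 4

The compounds below may be only part of what the source reports. "The series", "measured", "known", "first", "only" and "open" are said of these compounds alone.

Measured so far in a functional assay on SMMC-7721 cells (Homo sapiens) for cytotoxicity, read by MTT assay, with a stated time of 4 days; a lower number here means a stronger inhibitor, a higher number a weaker inhibitor:
- compound 1, `C=C1C(=O)[C@]23C[C@@]1(O)CC[C@H]2c1ccc(OS(=O)(=O)c2ccc(C)cc2)c(C)c1[C@@H]3Cn1cc(-c2ccc(Cl)cc2)nn1`: 6180 nM
- compound 2, `C=C1C[C@]23C[C@@]1(O)CC[C@@H]2c1cccc(C)c1[C@@H]3Cn1cc(-c2ccc(OC)cc2)nn1`: > 20000 nM, a limit of the assay and not a number
- compound 3, `C=C1C[C@]23C[C@@]1(O)CC[C@@H]2c1cccc(C)c1[C@@H]3Cn1cc(-c2ccc(Cl)cc2)nn1`: > 20000 nM, a limit of the assay and not a number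

Compound 3 therefore stands at the limit of > 20000 nM in this assay, at which 2 of the 3 values shown sit, and has no number of its own. Among the measured compounds shown here, the one step that would bear on it, a step that the two limits leave unreadable from compound 2 to compound 3, cannot be read because both ends of it are limits. For the measured compounds named here, compound 1 carries its own value, but it differs from compound 3 in more than one place, so the two values show no single step; they only show that compound 1 gives a number where compound 3 gives a limit.

Compound 4, `C=C1C[C@]23C[C@@]1(O)CC[C@@H]2c1cccc(C)c1[C@@H]3Cn1cc(-c2ccccn2)nn1`, is the next member: pyridin-2-yl in place of 4-chlorophenyl on an aromatic carbon. Going by the values given here, no measured step in this assay describes such an exchange, so nothing beyond the scatter can be predicted in either direction. The expectation for compound 4 in this assay is a value of 20000 nM, between 8000 nM and 50000 nM, which means an expected step of a number no higher from compound 3 to compound 4 (the limit leaves the size open), and most likely again only a limit.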

Compound 4, half-maximal inhibitory concentration: > 20000 nM
Compound 4: only a limit was reported; the forecaster's own chance of this, stated with the estimate: 70%; the middle value lies on the limit itself.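

Compound 4 gives > 20000 nM in this assay, a limit of the assay and not a number. Among the compounds shown here, no step among compound 2, compound 3 and compound 4 can be read, as all three sit at one limit: the limit of > 20000 nM in this assay, at which 3 of the 4 values shown sit. As far as these compounds go, what remains open is whether exchanging the aryl group on the five-membered ring changes the value at all.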